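Aryl sulfone variation on the dimethylaminoethyl side chain

A few compounds are considered here, and "the series" means these few. Any claim that something is new, unique, unknown or untested is made for them only; others in the source may bear on it.

The series is assessed in a functional assay on HeLa cells for agonist activity at 5-hydroxytryptamine receptor 6 (Homo sapiens), read by immunoassay; on this read-out lower numbers stand for an effect already at smaller amounts and higher numbers for an effect only at larger amounts of compound. Compound 1 `NCCn1cc(S(=O)(=O)c2ccccc2)c2ccccc21` gives 178 nM in this assay. Compound 2 `CN(C)CCn1cc(S(=O)(=O)c2ccccc2)c2cccnc21` gives 25 nM. Compound 3 `Cc1c(S(=O)(=O)c2ccccc2)c2cccnc2n1CCN(C)C` gives 47 nM. Of the three numbers shown, compound 2 stands at the lowest; compound 3 is its nearest neighbour, with a 1.9-fold higher number from compound 2 to compound 3 (0.27 log units; within the scatter) for methyl in place of hydrogen on an aromatic carbon, and compound 1 stands furthest, its number beyond the scatter from compound 2, though the two differ at more than one place and no single step connects them.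

Compound 4 `CN(C)CCn1cc(S(=O)(=O)c2ccc(Cl)s2)c2cccnc21` differs from compound 2 by 5-chlorothiophen-2-yl in place of phenyl on a sulfonyl sulfur. Among the measured compounds shown here, none of the measured steps touches the group on the sulfonyl sulfur: the only single-site step in the set concerns a methyl on the core and lies within the scatter. For the measured compounds named here, no measured step therefore bears on this change, and the data give no direction for it. The step expected here is a 1.2-fold higher number from compound 2 to compound 4 (0.08 log units; within the scatter), which should stay within the scatter. Compound 4 is estimated at 30 nM, with a range from 10 nM to 90 nM.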

Compound 4, half-maximal effective concentration: 32 nM
Compound 4: the middle estimate sits 1.1-fold (0.03 log units) below what was measured, and the stated range covers the measured number.
By their numbers in this assay, from the lowest: compounds 2, 4 and 3 (each within the scatter of the next); then compound 1.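

Notes on the group on the sulfonyl sulfur: the step of a 1.3-fold higher number from compound 2 to compound 4 (0.11 log units; within the scatter) in this assay is the first single-site reading at this place, which the earlier compounds left without any direction. Exchanging phenyl, a six-membered aromatic ring of carbon only, for 5-chlorothiophen-2-yl, a five-membered aromatic ring with 1 hetero atom, keeps the count of 6 heavy atoms, takes the hydrogen-bond acceptors from 0 to 1 and produces no difference that can be read beyond the scatter. Together with the core methyl step (a 1.9-fold higher number from compound 2 to compound 3 (0.27 log units; within the scatter)), this leaves both single-site changes from compound 2 within the scatter, although nothing measured accounts for the outcome at the sulfonyl sulfur.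

Going by these compounds, compound 4 changes the ring and adds chlorine in a single step, so the contribution of each stays open, and an unsubstituted thiophen-2-yl or a 4-chlorophenyl group on the sulfonyl sulfur would separate the two. Also open, on these data alone, is whether a larger group such as naphthyl, or an amine such as piperazinyl on the aromatic ring, would stay within the scatter of compound 2 at this place.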